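This account rests on a few compounds, and the source may have more. Where it says the series, first, only, none or still open, it means among the compounds named here.

Measured compounds:
compound 1 `O=C1CCC(N2C(=O)c3cccc(Nc4ccccc4)c3C2=O)C(=O)N1`, which in an assay on FRT-Jurkat cells for inhibition of nuclear factor NF-kappa-B complex (Homo sapiens), read by flow cytometry, with a stated time of 24 h, tested at 10 uM (on this read-out lower numbers stand for less inhibition and higher numbers for more inhibition at the one concentration tested (going by the name of the read-out)), gives 4%
compound 2 `O=C1CCC(N2C(=O)c3ccc(Nc4ccc(O)cc4)cc3C2=O)C(=O)N1`, which in this assay gives 4%

Compound 1 stands level with compound 2 at the digits shown; the two values lie within the scatter of each other, so neither can be placed above the other, and both sit at the low end of the inhibition scale. Among the compounds with values here, no pair of measured compounds differing in a single place is available, so no measured step frames the next change.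

Compound 3 `Cc1ccccc1Nc1cccc2c1C(=O)N(C1CCC(=O)NC1=O)C2=O` is derived from compound 1 by methyl in place of hydrogen on an aromatic carbon, a methyl entering on an aromatic carbon of a six-membered aromatic ring of carbon only. Within the data shown here, with compound 1 giving 4% and no measured step to guide the change, the expected step of a number 1 percentage points higher from compound 1 to compound 3 (within the scatter) is small, not beyond the scatter, in either direction. Compound 3 is therefore estimated to give 5% in this assay, within a range of -10% to 25%.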

Compound 3, a percentage reported as inhibition, at one concentration (the size of the read-out at that concentration, not a potency): 7%
Beside the measured number, compound 3's estimate is 2 percentage points below it, and the stated range covers the measured number.
By their numbers in this assay, from the lowest: compounds 1, 2 and 3 (each within the scatter of the next).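

In this assay, methyl in place of hydrogen on an aromatic carbon, ortho to a large group, amounts to a number 3 percentage points higher from compound 1 to compound 3 (within the scatter). The phenyl of the anilino group therefore takes this methyl at this place with no change that can be told from the scatter, and the result gives no sign that this single methyl moves the read-out in either direction. No measurement shown here offers an account of this step.

The compounds shown leave open whether an amine, a carboxylic acid or a longer chain at this same place would give a value beyond the scatter of compound 1. They also leave open whether a methoxy group or a chlorine atom elsewhere on that phenyl would do so.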